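The source may report more compounds than this note shows. Statements on the series, on what has been measured and on what is new or still open speak of the compounds shown alone.

Measured so far in an ADME assay on C6/36 cells (Aedes albopictus) for cytotoxicity, with a stated time of 1 weeks; on this read-out lower numbers stand for higher toxicity in this test and higher numbers for lower toxicity in this test:
compound 1 `O=c1ccn([C@H]2C[C@H](OC(c3ccccc3)(c3ccccc3)c3ccccc3)[C@@H](CO)O2)c(=O)[nH]1` gives 5000 nM
compound 2 `O=c1[nH]c(=O)n([C@@H]2O[C@H](COC(c3ccccc3)(c3ccccc3)c3ccccc3)[C@@H](O)[C@H]2OC(c2ccccc2)(c2ccccc2)c2ccccc2)cc1Cl` gives 30000 nM
compound 3 `O=c1[nH]cnc2c1ncn2[C@@H]1O[C@H](COC(c2ccccc2)(c2ccccc2)c2ccccc2)[C@@H](OC(c2ccccc2)(c2ccccc2)c2ccccc2)[C@H]1O` gives 10000 nM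

Compound 2 at 30000 nM has the highest of the three numbers. Both other compounds lie lower by more than the scatter, with compound 3 nearest and compound 1 furthest.

Compound 4 `O=c1[nH]cnc2c1ncn2[C@@H]1O[C@H](COC(c2ccccc2)(c2ccccc2)c2ccccc2)[C@@H](O)[C@H]1OC(c1ccccc1)(c1ccccc1)c1ccccc1` has not yet been measured. Its structural change from compound 2 is a group of 10 heavy atoms (5 carbon, 4 nitrogen, 1 oxygen; one five-membered aromatic ring with 2 hetero atoms, one six-membered aromatic ring with 2 hetero atoms) in place of a group of 9 heavy atoms (4 carbon, 2 nitrogen, 2 oxygen, 1 chlorine; one six-membered aromatic ring with 2 hetero atoms), on a saturated ring carbon and nothing else differs. Within the data shown here, the measured compounds include no pair that differs in one place, so no direct step is available to size this change. Among the measured compounds shown here, compound 3 carries the entering group and gives 10000 nM as the only guide. A moderate step towards a lower number is therefore expected, possibly not far beyond the scatter. The estimate means a 2.1-fold lower number from compound 2 to compound 4 (0.33 log units; beyond the scatter) as the expected step. Compound 4 is estimated at 14000 nM with an expected range from 5000 nM to 40000 nM for this read-out.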

Compound 4, half-maximal cytotoxic concentration: 6000 nM
The estimate for compound 4 lay 2.3-fold (0.37 log units) above the measured number; the measured number falls inside the stated range.
By their numbers in this assay, from the lowest: compounds 1, 4 and 3 (each within the scatter of the next); then compound 2.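

In this assay, replacing the group of 9 heavy atoms, with its one six-membered aromatic ring, by the group of 10 heavy atoms, with one five-membered and one six-membered aromatic ring, gives a 5.0-fold lower number from compound 2 to compound 4 (0.70 log units; beyond the scatter). Among these compounds, this is the first sized step and shows that the read-out responds to the group on this saturated ring carbon, next to the ring oxygen, while the rest of the structure stays the same. No measurement available here accounts for the size of this step.

A single pair cannot separate the contribution of the chlorine from that of the change in ring system. It also leaves open whether a bromine atom or a methyl group in place of the chlorine would shift the read-out in the same direction.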